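A few compounds are considered here, and "the series" means these few. Any claim that something is new, unique, unknown or untested is made for them only; others in the source may bear on it.

Three compounds from one series have been examined in an ADME assay on MDCK cells (Canis lupus familiaris) for cytotoxicity, read by microscopy, with a stated time of 48 h; a lower number here means that less compound is tolerated, a higher number that more compound is tolerated. Compound 1 `C[C@H]1[C@H](NCc2ccc(C(C)(C)C)s2)C[C@H]2C[C@@H]1C2(C)C` gives 780 nM. Compound 2 `C[C@H]1[C@H](NCc2ccc(Br)s2)C[C@H]2C[C@@H]1C2(C)C` gives 43000 nM, and compound 3 `C[C@H]1[C@H](NCc2sccc2C2CCCC2)C[C@H]2C[C@@H]1C2(C)C` gives 12500 nM. Compound 2 therefore stands at the top of the three numbers; its nearest neighbour is compound 3, and compound 1 lies furthest from it. Among the measured compounds shown here, the one step between compounds that differ in a single place is a 55-fold higher number from compound 1 to compound 2 (1.74 log units; beyond the scatter), where the bromo group on the aromatic carbon replaces the tert-butyl group and the tolerated concentration rises sharply.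

The next compound, compound 4 `C[C@H]1[C@H](NCc2nccs2)C[C@H]2C[C@@H]1C2(C)C`, differs from compound 2 in one place: 1,3-thiazol-2-yl in place of 5-bromothiophen-2-yl on a saturated chain carbon bound to an amine nitrogen. The entering ring is smaller than the one it replaces and carries one more hydrogen-bond acceptor. For the measured compounds named here, the only measured step that bears on this change is a 55-fold higher number from compound 1 to compound 2 (1.74 log units; beyond the scatter), which showed that shrinking the group on the thiophene ring raised the number in this assay by a large margin. On that basis compound 4 is expected to move further in the same direction or to stay within the scatter of compound 2, so the step of a 1.4-fold higher number from compound 2 to compound 4 (0.14 log units; within the scatter) is the estimate. Compound 4 is accordingly estimated at 60000 nM, within a range from 20000 nM to 200000 nM.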

Compound 4, minimum cytotoxic concentration: > 100000 nM
Compound 4: only a limit was reported (the forecaster's own chance of this, stated with the estimate: 25%); middle value at least 1.6-fold (0.22 log units) from the limit.
By their numbers in this assay, from the lowest: compound 1; then compound 3; then compound 2. At a limit, above all of these: compound 4.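

Among the compounds shown here, at this place, on a saturated chain carbon bound to an amine nitrogen, the earlier compounds showed only a change of the group carried on the thiophene ring, whereas this change replaces the ring itself. In this assay, 1,3-thiazol-2-yl in place of 5-bromothiophen-2-yl gives an at least 2.3-fold higher number from compound 2 to compound 4 (0.36 log units; beyond the scatter), so the series tolerates a five-membered aromatic ring with 2 hetero atoms and no bromine, and the number still rises beyond the scatter from an already high starting point. Compound 4 gives only a limit, so the step has a known floor but no known size: the limit of > 100000 nM in this assay, at which 1 of the 4 values shown sits.

The change removes the bromo group and brings a ring nitrogen in at the same time, so the compounds shown cannot say which of the two goes with the rise, and a plain thiophen-2-yl group or a bromo-substituted 1,3-thiazol-2-yl group would separate them. On these data alone, it also remains open whether a six-membered aromatic ring such as pyridin-2-yl, or a small chain such as a methyl or ethyl group on the 1,3-thiazol-2-yl ring, would keep the number at this limit.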